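The source may report more compounds than this note shows. Statements on the series, on what has been measured and on what is new or still open speak of the compounds shown alone.

Three compounds built on one shared core were tested in a functional assay on MDA-MB-468 cells (Homo sapiens) for cytotoxicity, read by sulforhodamine B assay, with a stated time of 48 h, tested at 1 uM; on this read-out lower numbers stand for a stronger effect and higher numbers for a weaker effect at the one concentration tested. Compound 1 `COc1cc(C)cc(-c2c(-c3ccnc(-c4ccc(C(C)=O)cc4)c3)cnn2CC#N)c1` gives -48% in this assay, and compound 2 `COc1cc(C)cc(-c2nn(CC#N)cc2-c2ccc(-c3cccc(C(C)=O)c3)nc2)c1` gives -42%. Compound 3 `Cc1cc(O)cc(-c2nn(CC#N)cc2-c2ccnc(-c3ccc(Oc4ccccc4)cc3)c2)c1` gives -62%, the lowest of the three numbers and so the strongest effect at the single concentration tested; compound 1 sits closest to it and compound 2 furthest, both beyond the usual scatter. Compound 4 `Cc1cc(O)cc(-c2nn(CC#N)cc2-c2ccnc(-c3ccc(N(C)C)cc3)c2)c1` has not yet been measured. It differs from compound 3 in one place: dimethylamino in place of phenoxy on an aromatic carbon. For the measured compounds named here, no measured pair shows what a change of this kind does, so the step is uncertain; a modest rise in the number, a weaker effect, is expected, as a number 12 percentage points higher from compound 3 to compound 4 (beyond the scatter). Compound 4 is therefore estimated at -50%, within a range from -75% to -20%.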

Compound 4, a percentage reported as activity, at one concentration (the size of the read-out at that concentration, not a potency): -50%
Estimate against measurement, compound 4: no gap at the digits printed; low and high end bracket the measured number.
By their numbers in this assay, from the lowest: compound 3; then compounds 4, 1 and 2 (each within the scatter of the next).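

In this assay, for the compounds shown here, putting dimethylamino in place of phenoxy on this aromatic carbon gives a number 12 percentage points higher from compound 3 to compound 4 (beyond the scatter), the first single-place change that can be read. The position therefore still gives a measurable effect with a group that has no ring, though a weaker one than with phenoxy. No measurement shown explains this shift. Open, on these data alone, is whether the ring, the oxygen or the group's size drives the step. A methoxy group, benzyloxy or a morpholine ring at this position could help separate these features.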